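Aryl amide exchange on the shared core

A few compounds are considered here, and "the series" means these few. Any claim that something is new, unique, unknown or untested is made for them only; others in the source may bear on it.

Three compounds of the series carry values in a functional assay on HepG2 cells (Homo sapiens) for cytotoxicity, read by MTT assay, with a stated time of 48 h; a higher number here means a weaker inhibitor, a lower number a stronger inhibitor. Compound 1 `COc1ccc(CNC(=O)CSc2nc3ccc(NC(=O)c4ccccc4OC)cc3s2)cc1` gives 2100 nM in this assay, the higher of the two numbers recorded, with compound 2 `O=C(CSc1nc2ccc(NC(=O)CCl)cc2s1)NCc1ccc(Cl)cc1` as its nearest neighbour at 1800 nM, a difference that sits within the scatter of repeated measurements. Compound 3 `CNC(=O)CSc1nc2ccc(NC(C)=O)cc2s1` reports only a limit of the assay, > 100000 nM, and not a number; the limit of > 100000 nM in this assay, at which 1 of the 3 values shown sits, marks where that limit lies. No pair among these three differs in a single place, so no measured step is available to anchor the next change.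

Compound 4 `COc1ccc(CNC(=O)CSc2nc3ccc(NC(=O)c4ccc(Cl)cc4)cc3s2)cc1` is the next compound to be measured in this assay. It differs from compound 1 as follows: 4-chlorophenyl in place of 2-methoxyphenyl on a carbonyl carbon. The amide side of the shared core is otherwise untouched.

With no measured step of this kind in hand, the expectation rests on the two numbers only: compound 1 at 2100 nM and compound 2 at 1800 nM lie close together despite different acyl groups on that nitrogen, so compound 4 is expected to change little, a step of a 1.1-fold lower number from compound 1 to compound 4 (0.02 log units; within the scatter) in either direction, not beyond the scatter. Compound 4 is thus estimated at 2000 nM in this assay, with a range from 700 nM to 6000 nM.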

Compound 4, half-maximal inhibitory concentration: 7400 nM
The estimate for compound 4 lay 3.7-fold (0.57 log units) below the measured number; the measured number lies above the stated range.
By their numbers in this assay, from the lowest: compounds 2 and 1 (each within the scatter of the next); then compound 4. At a limit, above all of these: compound 3.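

In this assay, within the data shown here, 4-chlorophenyl in place of 2-methoxyphenyl on a carbonyl carbon gives a 3.5-fold higher number from compound 1 to compound 4 (0.55 log units; beyond the scatter), the only step so far that can be read in a single place. The group on this carbonyl carbon is therefore not silent in this read-out: with the rest of the structure held fixed, the exchange alone moves the number beyond the scatter, though the step is modest and it points towards a weaker inhibitor. As a single pair, it gives a direction for this exchange and no trend for the position, and no measured property in the data at hand bears on the step.

The exchange removes the methoxy group and introduces the chlorine together, so the compounds shown cannot tell which of the two accounts for the higher number. Also open, going by these compounds, is how this assay responds at this carbonyl carbon to an unsubstituted phenyl, to a phenyl carrying a carboxylic acid, or to a saturated amine such as piperidine in place of the aryl ring.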